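A few compounds are considered here, and "the series" means these few. Any claim that something is new, unique, unknown or untested is made for them only; others in the source may bear on it.

Measured so far in an ADME assay on PANC-1 cells (Homo sapiens) for cytotoxicity, read by sulforhodamine B assay, with a stated time of 48 h, tested at 10 uM; a lower number here means less inhibition, a higher number more inhibition at the concentration tested (going by the name of the read-out):
Compound 1 `CCCCCc1cn(C(c2ccccc2)c2cc3cc(Br)ccc3nc2OC)nn1` gives 5.07%.
Compound 2 `COc1nc2ccc(Br)cc2cc1C(c1ccccc1)n1cc(CCCO)nn1` gives 25.5%.

Compound 2 stands highest of these two numbers; its nearest neighbour is compound 1, and the gap between them is beyond the scatter. Compound 3 `CCCc1cn(C(c2ccccc2)c2cc3cc(Br)ccc3nc2OC)nn1` is not yet measured. It differs from compound 2 by hydrogen in place of hydroxy on a saturated chain carbon, three bonds along the chain from an aromatic carbon. Going by the values given here, the one measured step that bears on this is a number 20.4 percentage points higher from compound 1 to compound 2 (beyond the scatter), where the hydroxy entered and the number rose by a modest amount. Taking the hydroxy away again is expected to undo most of that rise, so a modest fall in this assay is expected for compound 3, namely a number 17.5 percentage points lower from compound 2 to compound 3 (beyond the scatter), giving an estimate of 8% with a range from 0% to 22%.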

Compound 3, a percentage reported as inhibition, at one concentration (the size of the read-out at that concentration, not a potency): 11.3%
Beside the measured number, compound 3's estimate is 3.3 percentage points below it; low and high end bracket the measured number.
By their numbers in this assay, from the lowest: compounds 1 and 3 (each within the scatter of the next); then compound 2.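

Taking the hydroxy off the 3-hydroxypropyl group to leave propyl gives, in this assay, a number 14.2 percentage points lower from compound 2 to compound 3 (beyond the scatter), so the higher number now goes with the hydroxy on a chain of the same length, and not just with a change in chain length. The two chains without a hydroxy cannot be told apart, with a number 6.2 percentage points higher from compound 1 to compound 3 (within the scatter). Nothing measured here explains this. Going by these compounds, it remains open whether an amine or a carboxylic acid in the hydroxy's place would go the same way, and whether a hydroxy on a longer chain would keep the higher number.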